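Piperidin-3-yl in place of piperidin-4-yl

A few compounds are considered here, and "the series" means these few. Any claim that something is new, unique, unknown or untested is made for them only; others in the source may bear on it.

Compound 1 `C=CC(N)CCC(=O)N1CCC(C(=O)OC)CC1`: 150 umol/kg
Compound 2 `C=CC(CCC(=O)OC)NC(=O)C1CCNCC1`: 460 umol/kg

In a functional assay on the whole organism with Mus musculus as the target (a higher number here means that more compound is needed for the effect, a lower number that less compound is needed), compound 2 at 460 umol/kg has the higher of the two numbers, and the gap to compound 1 lies beyond the scatter. Compound 3 `C=CC(CCC(=O)OC)NC(=O)C1CCCNC1` has the same atoms as compound 2, joined differently, with piperidin-3-yl in place of piperidin-4-yl on a carbonyl carbon. Among the compounds with values here, no measured pair shows this kind of change, so no step beyond the scatter is expected in this assay. The estimated change is a 1.4-fold lower number from compound 2 to compound 3 (0.14 log units; within the scatter). For compound 3 the expected value is 330 umol/kg, with an estimated range of 130 umol/kg to 800 umol/kg.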

Compound 3, dose for half-maximal effect: 310 umol/kg
For compound 3 the middle estimate is 1.1-fold (0.03 log units) above the measured one; measured number inside the range.
By their numbers in this assay, from the lowest: compound 1; then compounds 3 and 2 (each within the scatter of the next).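

In this assay the step at this position, with piperidin-3-yl in place of piperidin-4-yl on a carbonyl carbon, is a 1.5-fold lower number from compound 2 to compound 3 (0.17 log units; within the scatter) and so gives no distinguishable change. On these numbers, the two attachments of the piperidine ring cannot be told apart at this position. Nothing available explains this result.

As far as these compounds go, whether piperidin-2-yl or pyrrolidin-3-yl on the same carbonyl carbon would also stay within the scatter remains open. So does the effect of a carboxylic acid in place of the methyl ester.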